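A Methyl Group Added to Compound 1: Cytotoxicity Outlook

The source may report more compounds than this note shows. Statements on the series, on what has been measured and on what is new or still open speak of the compounds shown alone.

Compound 1 `O=C(Nc1cccc(-c2nc3ccccc3[nH]2)c1)c1cccs1` was measured in an ADME assay on NIH3T3 cells (Mus musculus) for cytotoxicity, read by resazurin assay, with a stated time of 48 h (on this read-out lower numbers stand for stronger inhibition and higher numbers for weaker inhibition), and gives 15000 nM, the lowest of the three numbers recorded. Compound 2 `O=C(Nc1cccc(-c2nc3ccccc3[nH]2)c1)C1CCCCC1` gives 22200 nM, and compound 3 `O=C(Nc1ccccc1-c1nc2ccccc2[nH]1)NC1CCCCC1` gives 42200 nM. Among the measured compounds shown here, the only step between two compounds that differ in one place, a 1.5-fold higher number from compound 1 to compound 2 (0.17 log units; within the scatter), shows how little an exchange at the carbonyl carbon moved the read-out. Compound 4 `Cc1ccc2[nH]c(-c3cccc(NC(=O)c4cccs4)c3)nc2c1` differs from compound 1 by methyl in place of hydrogen on an aromatic carbon. For the measured compounds named here, no measured step touches that ring, and the one known step stayed within the scatter, so no shift beyond the scatter is expected in either direction. For compound 4 the expected number is 14000 nM, with a range from 6000 nM to 35000 nM, amounting to an expected 1.1-fold lower number from compound 1 to compound 4 (0.03 log units; within the scatter).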

Compound 4, half-maximal inhibitory concentration: 16700 nM
Beside the measured number, compound 4's estimate is 1.2-fold (0.08 log units) below it; low and high end bracket the measured number.
By their numbers in this assay, from the lowest: compounds 1, 4, 2 and 3 (each within the scatter of the next, the first and the last beyond it).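

In this assay, methyl in place of hydrogen on an aromatic carbon of the six-membered ring of the fused system gives a 1.1-fold higher number from compound 1 to compound 4 (0.05 log units; within the scatter) and so stays within the scatter. Among the compounds shown here, this is the first reading from that ring, which the earlier compounds left untouched, and it shows that this single added carbon leaves the number where it was. Nothing available bears on what lies behind this result.

Going by these compounds, whether an amine, a carboxylic acid or a longer chain on this carbon would also stay within the scatter remains open. So does whether methyl on the ring's other carbons would read the same.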